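The source may report more compounds than this note shows. Statements on the series, on what has been measured and on what is new or still open speak of the compounds shown alone.

Working notes on the series. In a functional assay (mast cells) for inhibition, with Rattus norvegicus as the target (on this read-out lower numbers stand for an effect already at smaller amounts and higher numbers for an effect only at larger amounts of compound), compound 1 `CC1CC/C(=N\Nc2ccc(F)cc2)c2ncc(C(=O)O)c(=O)n21` gives 1200 nM and compound 2 `CC1CC/C(=N\Nc2ccc(C(F)(F)F)cc2)c2ncc(C(=O)O)c(=O)n21` gives 280 nM. For the measured compounds named here, compound 2 therefore holds the lower of the two numbers so far. Compound 3 `CC(C)c1ccc(N/N=C2\CCC(C)n3c2ncc(C(=O)O)c3=O)cc1` differs from compound 2 by isopropyl in place of trifluoromethyl on an aromatic carbon, in words isopropyl in place of trifluoromethyl on an aromatic carbon, para to a large group.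

Going by the values given here, only one measured step bears on this change: a 4.3-fold lower number from compound 1 to compound 2 (0.63 log units; beyond the scatter). That step, trifluoromethyl in place of fluoro at the same place, is modest and beyond the scatter. Among the compounds with values here, it shows that this assay responds to a change at this place, but no measured compound carries isopropyl there, so the direction of the new step remains uncertain. Within the data shown here, since compound 2 is the lower of only two values, a small move towards a higher number is expected, no larger than the one measured step and possibly within the scatter. The estimated step is a 1.6-fold higher number from compound 2 to compound 3 (0.21 log units; within the scatter). For compound 3 the expected value is 450 nM, with an estimated range from 130 nM to 1300 nM.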

Compound 3, half-maximal effective concentration: 1200 nM
Compound 3: the middle estimate sits 2.7-fold (0.43 log units) below what was measured; the range from low to high includes it.
By their numbers in this assay, from the lowest: compound 2; then compounds 1 and 3 (each within the scatter of the next).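

In this assay, exchanging trifluoromethyl for isopropyl on the aromatic carbon para to a large group gives a 4.3-fold higher number from compound 2 to compound 3 (0.63 log units; beyond the scatter) and so reverses the whole gain seen on the earlier change at this place. Isopropyl against fluoro gives no change at the digits printed from compound 1 to compound 3 (within the scatter), which means that compound 2 now stands apart from both other compounds, each by a step beyond the scatter, and that the position does not simply reward any group larger than fluoro. The heavy-atom counts point the same way, with 3 for isopropyl and 4 for trifluoromethyl lying close together while the read-out separates the two compounds; nothing on hand explains why trifluoromethyl alone holds the lower number.

The compounds shown leave open whether a nitrile, a methoxy group or a chloro substituent at this place would fall with trifluoromethyl or with fluoro and isopropyl. They also leave open whether a longer chain, such as tert-butyl or an n-propyl group, would keep the number where isopropyl has it.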